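Series notes: cytotoxicity step from compound 3 to compound 4

A few compounds are considered here, and "the series" means these few. Any claim that something is new, unique, unknown or untested is made for them only; others in the source may bear on it.

Of the compounds shown here, three sharing one core have been measured in a functional assay on PC-12 cells (Rattus norvegicus) for cytotoxicity, read by MTT assay, with stated times of 3 h and 2 h, tested at 20 uM; a lower number here means a weaker effect, a higher number a stronger effect of the compound at the concentration tested. Compound 1 `O=C(CCCCC1CCSS1)NCc1cn(CCCCOc2ccc3cc(-c4ccccc4)c(=O)oc3c2)nn1` gives 26%, compound 2 `O=C(CCCCC1CCSS1)NCc1cn(CCCCOc2ccc3cc(-c4ccc(Cl)cc4)c(=O)oc3c2)nn1` gives 68.4%, and compound 3 `CC(=O)c1cc2ccc(OCCCCCn3cc(CNC(=O)CCCCC4CCSS4)nn3)cc2oc1=O` gives 20.7%. Compound 3 stands at the low end of the set: its number and that of compound 1 lie within the scatter of each other, while compound 2 lies higher beyond the scatter. For the measured compounds named here, the only single-point step measured so far is a number 42.4 percentage points higher from compound 1 to compound 2 (beyond the scatter).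

Compound 4 `COc1ccc(-c2cc3ccc(OCCCCCn4cc(CNC(=O)CCCCC5CCSS5)nn4)cc3oc2=O)cc1` is the next member. Relative to compound 3 the change is 4-methoxyphenyl in place of acetyl on an aromatic carbon. Going by the values given here, no measured step covers this kind of exchange; the chloro-for-hydrogen step from compound 1 to compound 2 concerns a different place and a different group and offers no direct guide. The nearest point of comparison is compound 1, which carries an unsubstituted phenyl at the same place and gives 26%, close to compound 3. On these data alone, on that basis no step beyond the scatter is expected in this assay, with the range kept wide because the change is untested.

Compound 4 is expected to give 28%, within 12% to 50%. The estimated step is a number 7.3 percentage points higher from compound 3 to compound 4 (within the scatter).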

Compound 4, a percentage reported as activity, at one concentration (the size of the read-out at that concentration, not a potency): 49%
For compound 4 the middle estimate is 21 percentage points below the measured one; measured number inside the range.
By their numbers in this assay, from the lowest: compounds 3 and 1 (each within the scatter of the next); then compound 4; then compound 2.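

In this assay the aromatic carbon two atoms from the ring oxygen responds to a change of group: 4-methoxyphenyl in place of acetyl gives a number 28.3 percentage points higher from compound 3 to compound 4 (beyond the scatter), the only step shown at this position. The exchange replaces a group of 3 heavy atoms with no ring by one of 8 heavy atoms with a six-membered aromatic ring, while each group holds 1 hydrogen-bond acceptor, so the step comes with a change in size and ring content and no change in that count. No measurement shown bears on why the number rises.

The compounds shown do not separate the contribution of the aromatic ring from that of its methoxy group, as compound 1 and compound 4 differ in more than one place. Also open, on these data alone, is how this position behaves with an amine or a carboxylic acid on the aromatic ring, or with a simple alkyl group such as ethyl in place of the acetyl of compound 3.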